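Hydroxyalkyl variation at the ring nitrogen, compound 2 to 3

The source may hold more compounds than are shown below. What is called first, only, known or untested is meant among the compounds shown, and "the series" means these compounds.

Compound 1 `N=c1c2c(-c3ccccc3)c(-c3ccccc3)n(Cc3ccccc3)c2ncn1C1CCN(Cc2ccccc2)CC1` in a functional assay on PC-3M cells (Homo sapiens) for antiproliferative activity, read by microscopy, with a stated time of 24 h (on this read-out higher numbers stand for weaker inhibition and lower numbers for stronger inhibition), gives 5010 nM; 5010 nM (2 entries), measured twice. Compound 2 `COc1ccc(-c2c(-c3ccc(OC)cc3)n(Cc3ccccc3)c3ncn(CCO)c(=N)c23)cc1` stands on a limit of this assay alone, reported as > 20000 nM, so no number is known for it. One of the two values shown thus sits at the limit of > 20000 nM in this assay, at which 1 of the 2 values shown sits. Compound 3 `COc1ccc(-c2c(-c3ccc(OC)cc3)n(Cc3ccccc3)c3ncn([C@H]4CC[C@H](O)CC4)c(=N)c23)cc1` differs from compound 2 by 4-hydroxycyclohexyl in place of 2-hydroxyethyl on an aromatic nitrogen. For the measured compounds named here, no measured step between close analogues is known here, so the expected step is none beyond the usual scatter, expressed as an at least 1.3-fold lower number from compound 2 to compound 3 (0.12 log units; that floor lies within the scatter). Compound 3 is estimated at 15000 nM, with a range from 4000 nM to 50000 nM.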

Compound 3, half-maximal inhibitory concentration: > 20000 nM
Compound 3: a limit, no number; the forecaster's own chance of this, stated with the estimate: 50%; middle value at least 1.3-fold (0.12 log units) away from the limit.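

No step can be read from compound 2 to compound 3, since both results are limits: the limit of > 20000 nM in this assay, at which 2 of the 3 values shown sit. From the compounds shown here alone, whether 4-hydroxycyclohexyl or 2-hydroxyethyl on the aromatic nitrogen gives stronger inhibition remains open.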